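Cyclopentyl for benzyl on the shared core

The source may report more compounds than this note shows. Statements on the series, on what has been measured and on what is new or still open speak of the compounds shown alone.

Measured so far:
compound 1 `COc1ccc(-c2cnc3nc(N)nc(N4CCN(C(=O)Nc5ccc(C)cc5)CC4)c3n2)cc1OC`: 0.8 nM
compound 2 `COc1ccc(-c2cnc3nc(N)nc(NCc4ccccc4)c3n2)cc1OC`: 13000 nM
compound 3 `COc1ccc(-c2cnc3nc(N)nc(N4CCN(Cc5ccccc5F)CC4)c3n2)cc1OC`: 700 nM

In a functional assay on cells (T-cell, Homo sapiens) for inhibition (a higher number here means a weaker inhibitor, a lower number a stronger inhibitor), compound 2 stands at the highest number of the three, beyond the scatter from both others; compound 3 gives 700 nM and compound 1 gives 0.8 nM. Compound 4 `COc1ccc(-c2cnc3nc(N)nc(NC4CCCC4)c3n2)cc1OC` differs from compound 2 by cyclopentyl in place of benzyl on a nitrogen on an aromatic ring. For the measured compounds named here, the only measured step, an 880-fold higher number from compound 1 to compound 3 (2.94 log units; beyond the scatter), concerns the amine nitrogen in a ring and not the nitrogen on an aromatic ring changed here, so it does not bear on this change. Going by the values given here, no step shows what cyclopentyl in place of benzyl does on this nitrogen; compound 2 already gives a high number, and a step of no size beyond the scatter is expected, a 1.2-fold higher number from compound 2 to compound 4 (0.06 log units; within the scatter). Compound 4 is therefore estimated at 15000 nM, within 3000 nM to 60000 nM.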

Compound 4, half-maximal inhibitory concentration: 800 nM
Estimate against measurement, compound 4: 19-fold (1.27 log units) above, outside the stated range (below it).
By their numbers in this assay, from the lowest: compound 1; then compounds 3 and 4 (each within the scatter of the next); then compound 2.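

In this assay, the nitrogen on an aromatic ring responds strongly to its substituent: cyclopentyl in place of benzyl gives a large step (a 16-fold lower number from compound 2 to compound 4 (1.21 log units; beyond the scatter)). The high number of compound 2 therefore belongs to the benzyl group and not to the benzylamino link as such. Nothing at hand gives a reason for this step. The step changes ring size and aromaticity together, so the compounds shown do not separate the two. Cyclohexyl on this nitrogen would address that, and a simple methyl would show whether any ring is needed here.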